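A few compounds are considered here, and "the series" means these few. Any claim that something is new, unique, unknown or untested is made for them only; others in the source may bear on it.

Compound 3 `Clc1ccc2ncnc(NCc3ccccc3)c2c1` has a chloro on the shared core and a pendant ring joined to it through a short link. In a functional assay on HEK293 cells for antagonist activity at metabotropic glutamate receptor 5 (Rattus norvegicus), read by calcium flux (a higher number here means a weaker inhibitor, a lower number a stronger inhibitor), compound 3 gives > 30000 nM, which is a limit of the assay rather than a measured number. Compound 3 therefore stands at the far end of the numbers shown, at the limit of > 30000 nM in this assay, at which 1 of the 3 values shown sits. Compound 1 `Brc1ccc2ncnc(Nc3ccccc3)c2c1` carries a bromo on the core and a pendant ring joined directly through the amine. In this assay compound 1 gives > 10000 nM, also a limit rather than a number; this is the limit of > 10000 nM in this assay, at which 1 of the 3 values shown sits. Compound 2 `Brc1cccc(Nc2ncnc3ccc(Br)cc23)c1` adds a bromo to that pendant ring. In this assay compound 2 gives 174 nM. Going by the values given here, the step of an at least 57-fold lower number from compound 1 to compound 2 (1.75 log units; beyond the scatter) is the one measured change that resembles the move to compound 4 `Clc1ccc(CNc2ncnc3ccc(Cl)cc23)cc1`: chloro in place of hydrogen on an aromatic carbon. There a halogen entered the pendant ring and the number fell steeply. A comparable change is expected to pull the number of compound 4 down by roughly an at least 6.0-fold lower number from compound 3 to compound 4 (0.77 log units; beyond the scatter), although compound 3 starts from a limit and its link differs. Compound 4 is estimated at 5000 nM, between 500 nM and 30000 nM.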

Compound 4, half-maximal inhibitory concentration: > 30000 nM
Compound 4 ended at the assay's limit; the forecaster's own chance of this, stated with the estimate: 35%; middle value at least 6.0-fold (0.77 log units) away from the limit.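

Compound 3 and compound 4 both end at a limit of this assay rather than at a number, and the step between them cannot be read. The compounds shown leave open whether the chloro on the pendant ring of compound 4 changes inhibition at all.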